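The compounds below may be only part of what the source reports. "The series", "measured", "known", "first", "only" and "open" are said of these compounds alone.

Measured so far:
- compound 1, `O=C1CSC(c2cccc(O)c2)N1CCN1CCCCC1`: 13%
- compound 2, `O=C1CSC(c2cccc(F)c2)N1CCN1CCCCC1`: 17%

In an ADME assay on Vero cells (Chlorocebus sabaeus) for cytotoxicity, read by neutral red uptake, tested at 1575 ug/mL (on this read-out higher numbers stand for a weaker effect at the one concentration tested and lower numbers for a stronger effect), compound 1 gives 13%, and compound 2 gives 17%. Within the data shown here, the one step between them, a number 4 percentage points higher from compound 1 to compound 2 (within the scatter), is too small to tell the two apart, so compound 2 stands together with compound 1, both with low numbers in this assay.

Compound 3, `COc1cccc(C2SCC(=O)N2CCN2CCCCC2)c1`, differs from compound 2 in one place: methoxy in place of fluoro on an aromatic carbon. Among the measured compounds shown here, the only measured step that bears on this place is the one from compound 1 to compound 2, a number 4 percentage points higher from compound 1 to compound 2 (within the scatter), which stayed within the scatter when the group on that aromatic carbon was changed. On that basis the step from compound 2 to compound 3 in this assay is expected to be small as well, a number 1 percentage points lower from compound 2 to compound 3 (within the scatter), with no clear direction. Compound 3 is therefore estimated at 16% in this assay, within the range 5% to 32%.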

Compound 3, a percentage reported as activity, at one concentration (the size of the read-out at that concentration, not a potency): 11%
Beside the measured number, compound 3's estimate is 5 percentage points above it, within the range that was stated.
By their numbers in this assay, from the lowest: compounds 3, 1 and 2 (each within the scatter of the next).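

In this assay a third group now sits on this aromatic carbon, and it does not separate from the other two: methoxy in place of fluoro gives a small step (a number 6 percentage points lower from compound 2 to compound 3 (within the scatter)), and so does methyl in place of hydrogen on the oxygen (a number 2 percentage points lower from compound 1 to compound 3 (within the scatter)). The earlier pair compared only hydroxy and fluoro, so this adds that capping the hydroxy oxygen with methyl, which also makes the group larger by one carbon, leaves the reading within the scatter across all three compounds. Nothing measured here offers an explanation for why the three groups read alike.

Still open, on these data alone, is whether a group of another kind on this carbon, such as an amine or a carboxylic acid, or a longer chain on the oxygen, such as ethoxy, would stay within the scatter too. All three compounds carry their group at this one place, so they say nothing about changes elsewhere on the ring or in the rest of the molecule.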